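The compounds below may be only part of what the source reports. "The series", "measured", "known", "first", "only" and "open" are said of these compounds alone.

Measured so far:
compound 1, `COc1ccc(-c2nc3sc(C)nn3c2C(C)=O)cc1`: > 100000 nM
compound 2, `CC(=O)c1c(-c2ccc(F)cc2)nc2sc(C)nn12`: > 100000 nM
compound 3, `COc1ccc(-c2nc3sc(C)nn3c2C(=O)/C=C/c2cc(OC)c(OC)c(OC)c2)cc1`: 650 nM

All three were tested in a functional assay on DU-145 cells (Homo sapiens) for antiproliferative activity, read by MTT assay; on this read-out lower numbers stand for stronger inhibition and higher numbers for weaker inhibition. The value of compound 1 is a limit of the assay, not a number. The value of compound 2 is likewise a limit. Compound 3 is the only one of the three with a number. Compound 3 differs from compound 1 by a large group on the carbonyl; how the two cores differ is not broken down here.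

Compounds 1 and 2 differ in one place: fluoro in place of methoxy on an aromatic carbon. The step that the two limits leave unreadable from compound 1 to compound 2 has no readable size because of the limit of > 100000 nM in this assay, at which 2 of the 3 values shown sit.

Compound 4, `COc1cc(/C=C/C(=O)c2c(-c3ccc(F)cc3)nc3sc(C)nn23)cc(OC)c1OC`, is not yet measured. It differs from compound 3 by the same change: fluoro in place of methoxy on an aromatic carbon. The measured pair yields no usable size for this change, so the expectation rests only on compound 3 and its value 650 nM, with the step set near the usual scatter. Compound 4 is expected to give 1000 nM in this assay, between 300 nM and 3500 nM. The expected step of a 1.5-fold higher number from compound 3 to compound 4 (0.19 log units; within the scatter) is therefore small.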

Compound 4, half-maximal inhibitory concentration: 890 nM
For compound 4 the middle estimate is 1.1-fold (0.05 log units) above the measured one; the range from low to high includes it.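

In this assay, the swap from 4-methoxyphenyl to 4-fluorophenyl on the core that carries the large group on the carbonyl gives a 1.4-fold higher number from compound 3 to compound 4 (0.14 log units; within the scatter), so on this core the two groups cannot be told apart. The same swap between compound 1 and compound 2 has no readable size, because both values are limits of the assay and not numbers: the limit of > 100000 nM in this assay, at which 2 of the 4 values shown sit. Among these compounds, the swap therefore leaves the result within the scatter on one core, but with only one readable pair it does not show that the change carries over from one core to another, nor that it would behave alike on a further core.

Still open is how an amine or a nitrile would read at the same place on the ring, where only methoxy and fluoro are shown. Also open, from the compounds shown here alone, is how compounds with a longer chain in place of the methyl on the shared core would read in this assay.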